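Adding fluoro to compound 3

This account rests on a few compounds, and the source may have more. Where it says the series, first, only, none or still open, it means among the compounds named here.

Measured in a functional assay on HCT-116 cells (Homo sapiens) for antiproliferative activity, with a stated time of 72 h; a higher number here means a weaker inhibitor, a lower number a stronger inhibitor:
- compound 1 `C=C1C=CC(=O)[C@@H]2[C@H](Cc3ccc(OCOC)c(F)c3)CC[C@H]12`: 77.4 nM
- compound 2 `C=C1C=CC(=O)[C@@H]2[C@H](Cc3ccc(OC)c(F)c3)CC[C@H]12`: 1.11 nM
- compound 3 `C=C1C=CC(=O)[C@@H]2[C@H](Cc3ccc(O)cc3)CC[C@H]12`: 38.5 nM

In this assay compound 3 gives 38.5 nM, within the scatter of compound 1, and well above compound 2 at 1.11 nM. Compound 4 `C=C1C=CC(=O)[C@@H]2[C@H](Cc3ccc(O)c(F)c3)CC[C@H]12` differs from compound 3 by fluoro in place of hydrogen on an aromatic carbon, ortho to a hydroxy group.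

Going by the values given here, no measured step isolates this change. Among the compounds with values here, the only step available, a 70-fold lower number from compound 1 to compound 2 (1.84 log units; beyond the scatter), is large, but it joins two compounds that both carry fluoro, so it shows only that values among fluoro compounds can differ widely. Compounds 1 and 2 bracket a broad range, and compound 3 without fluoro falls inside it. A modest move towards a lower number is therefore expected, with no change beyond the scatter still possible. The expected step is a 2.6-fold lower number from compound 3 to compound 4 (0.41 log units; beyond the scatter). For compound 4 the estimated value is 15 nM, with an expected range of 3 nM to 60 nM.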

Compound 4, half-maximal inhibitory concentration: 126 nM
For compound 4 the middle estimate is 8.4-fold (0.92 log units) below the measured one, outside the stated range (above it).
By their numbers in this assay, from the lowest: compound 2; then compounds 3, 1 and 4 (each within the scatter of the next, the first and the last beyond it).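

In this assay, going by these compounds alone, fluoro in place of hydrogen on an aromatic carbon, ortho to a hydroxy group, gives a 3.3-fold higher number from compound 3 to compound 4 (0.51 log units; beyond the scatter) with the hydroxy group free, so fluoro at this position brings no gain in this pair. With fluoro present, the group on the oxygen separates the values unevenly: hydrogen in place of methyl gives a 110-fold higher number from compound 2 to compound 4 (2.06 log units; beyond the scatter) while hydrogen in place of methoxymethyl gives a 1.6-fold higher number from compound 1 to compound 4 (0.21 log units; within the scatter) and so no change that can be told from scatter. No measurement at hand accounts for any of these steps.

As far as these compounds go, whether fluoro at this carbon moves the number the same way when methyl sits on the oxygen stays open. So does how chlorine at this carbon, or an ethyl or longer chain on the oxygen, would compare.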